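Ethyl to Methyl on a Shared Core: Maximal Response Expected

The source may hold more compounds than are shown below. What is called first, only, known or untested is meant among the compounds shown, and "the series" means these compounds.

Measured compounds:
Compound 1 `Cn1cccc1-c1ccccc1NCC1=NCCN1` gives 103%.
Compound 2 `CCn1nccc1-c1ccccc1NCC1=NCCN1` gives 81%.

Both were tested in a functional assay with Alpha-1A adrenergic receptor (Homo sapiens) as the target, read by calcium flux; on this read-out lower numbers stand for smaller maximal responses and higher numbers for larger maximal responses. Compound 2 stands lowest of the two numbers, and compound 1 sits higher by a gap beyond the usual scatter. Compound 3 `Cn1nccc1-c1ccccc1NCC1=NCCN1` has not yet been measured. It differs from compound 2 in a single place: hydrogen in place of methyl on a saturated chain carbon bound to an aromatic nitrogen. Cut one bond further out, the same change reads as ethyl to methyl.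

Within the data shown here, no step between two measured compounds with this kind of change exists here, so the direction rests only on the two values shown. A small step from compound 2 to compound 3 is expected, upward if anything, and likely no larger than the usual scatter. On that basis compound 3 is expected to give about 90%, within a range from 70% to 108%. The expected step is a number 9 percentage points higher from compound 2 to compound 3 (within the scatter).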

Compound 3, largest response reached (reported as maximal response), in percent of the reference or control that the assay uses: 108%
For compound 3 the middle estimate is 18 percentage points below the measured one, and the stated range covers the measured number.
By their numbers in this assay, from the lowest: compound 2; then compounds 1 and 3 (each within the scatter of the next).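

In this assay, the change from ethyl to methyl gives a number 27 percentage points higher from compound 2 to compound 3 (beyond the scatter), which shows that a single carbon at this place on the group bound to an aromatic nitrogen can shift the maximal response beyond the scatter. With the methyl kept, 1-methyl-1H-pyrazol-5-yl in place of 1-methyl-1H-pyrrol-2-yl on an aromatic carbon gives a number 5 percentage points higher from compound 1 to compound 3 (within the scatter), so this read-out does not separate these two groups. Nothing measured here explains why the ethyl group gives the smaller response.

As far as these compounds go, whether a longer chain such as propyl or a branched one such as isopropyl would lower the response further remains open. Among these compounds, also open is whether ethyl to methyl does the same elsewhere, since this single pair is the only example of the change.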